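The source may hold more compounds than are shown below. What is called first, only, known or untested is meant among the compounds shown, and "the series" means these compounds.

Compound 2 (`Oc1ccccc1-c1cc(-c2cccc(OC(F)(F)F)c2)cc(-c2ccccc2O)n1`) and compound 1 (`Oc1cccc(-c2cc(-c3cccc(F)c3)cc(-c3ccccc3O)n2)c1`) share a core that carries three aryl groups. In a functional assay on T47D cells (Homo sapiens) for inhibition (a higher number here means a weaker inhibitor, a lower number a stronger inhibitor), compound 2 reaches only the limit of the assay, > 50000 nM, and not a number. Compound 1 likewise gives only a limit in this assay, > 50000 nM. For the measured compounds named here, both values sit at the limit of > 50000 nM in this assay, at which 2 of the 2 values shown sit, so compound 2 stands level with the only other measured compound and no order between them can be read. Compound 3 (`Oc1cccc(-c2cc(-c3cccc(OC(F)(F)F)c3)cc(-c3ccccc3O)n2)c1`) is not yet measured; it differs from compound 2 by 3-hydroxyphenyl in place of 2-hydroxyphenyl on an aromatic carbon, next to the ring nitrogen, the two structures holding the same atoms joined differently. Going by the values given here, no measured pair shows this exact change, but compound 1, which also carries a 3-hydroxyphenyl group, gives > 50000 nM, a limit. A step of no size beyond the scatter in this assay is expected, most likely another limit. Compound 3 is therefore estimated at 70000 nM, within 20000 nM to 250000 nM, the step that the limit leaves unreadable from compound 2 to compound 3 being expected to stay within the scatter.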

Compound 3, half-maximal inhibitory concentration: 5390 nM
Beside the measured number, compound 3's estimate is 13-fold (1.11 log units) above it; measured number below the stated range.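

In this assay, with trifluoromethoxy held constant, 3-hydroxyphenyl in place of 2-hydroxyphenyl on the aromatic carbon next to the ring nitrogen gives an at least 9.2-fold lower number from compound 2 to compound 3 (0.96 log units; beyond the scatter), so a change that keeps the same atoms but joins them differently separates a measurable compound from one at the limit. For the compounds shown here, with 3-hydroxyphenyl held constant, trifluoromethoxy in place of fluoro gives an at least 9.2-fold lower number from compound 1 to compound 3 (0.96 log units; beyond the scatter), and compound 3, the only one of the three carrying both groups, is the only one to give a number. Both steps are only lower bounds, because compound 1 and compound 2 give limits and not numbers: the limit of > 50000 nM in this assay, at which 2 of the 3 values shown sit.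

As far as these compounds go, the true size of either step remains open. From the compounds shown here alone, it is also open whether the hydroxyl of the 3-hydroxyphenyl group could give way to an amine or a methoxy group, or the trifluoromethoxy group to a carboxylic acid.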